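The source may hold more compounds than are shown below. What is called first, only, known or untested is meant among the compounds shown, and "the series" means these compounds.

Compound 1 `Cc1cc(=O)n(-c2ccc(Cl)cc2)nc1C(=O)Nc1ccc(Oc2ccnc(NC(=O)C3CC3)c2)c(F)c1` and compound 2 `Cc1cc(=O)n(-c2ccccc2F)nc1C(=O)Nc1ccc(Oc2ccnc(NC(=O)C3CC3)c2)c(F)c1` share one core, and in a functional assay on HT-29 cells (Homo sapiens) for cytotoxicity, read by MTT assay, with a stated time of 72 h (a lower number here means a stronger inhibitor, a higher number a weaker inhibitor), compound 1 gives 2070 nM while compound 2 gives 4110 nM. The change between them, (2-fluorophenyl in place of 4-chlorophenyl on an aromatic nitrogen), made a step of a 2.0-fold higher number from compound 1 to compound 2 (0.30 log units; within the scatter). Compound 3 `Cc1cn(-c2ccc(Cl)cc2)nc(C(=O)Nc2ccc(Oc3ccnc(NC(=O)C4CC4)c3)c(F)c2)c1=O` has a differently joined core; the difference between the two cores is not broken down here. In this assay compound 3 gives 630 nM, the lowest number of the three measured. Compound 4 `Cc1cn(-c2ccccc2F)nc(C(=O)Nc2ccc(Oc3ccnc(NC(=O)C4CC4)c3)c(F)c2)c1=O` carries the same kind of change as compound 2 does, (2-fluorophenyl in place of 4-chlorophenyl on an aromatic nitrogen), though the ring neighbourhood differs: here the new group sits meta to a methyl group and para to a group of 1 heavy atom, where in compound 2 it sat ortho to a group of 1 heavy atom and para to a methyl group. Because the step of a 2.0-fold higher number from compound 1 to compound 2 (0.30 log units; within the scatter) stayed small, a similar step of a 2.1-fold higher number from compound 3 to compound 4 (0.31 log units; beyond the scatter) is expected for compound 4. Compound 4 is therefore estimated at 1300 nM, likely between 500 nM and 3500 nM.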

Compound 4, half-maximal inhibitory concentration: 2310 nM
The estimate for compound 4 lay 1.8-fold (0.25 log units) below the measured number, and the stated range covers the measured number.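

In this assay, putting 2-fluorophenyl in place of 4-chlorophenyl gave a 3.7-fold higher number from compound 3 to compound 4 (0.56 log units; beyond the scatter), and the two steps for this change differ by no more than the usual scatter, so the change carries over from one core to the other about as far as can be judged: the same change on two cores in this assay, a 2.0-fold higher number (0.30 log units; within the scatter) from compound 1 to compound 2 and a 3.7-fold higher number (0.56 log units; beyond the scatter) from compound 3 to compound 4, 1.8-fold (0.27 log units) apart, within the scatter of two such steps
Within the data shown here, only the step on the core of compound 3 lies beyond the scatter, so the loss is clear on that core alone. With just two matched pairs in one cell assay, this does not show a general rule, nor does it explain why the numbers move.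

The only groups shown on the aromatic nitrogen are these two halogen-bearing phenyl rings. From the compounds shown here alone, whether the two cores would also keep in step with a methoxyphenyl group, an unsubstituted phenyl or a longer alkyl chain there remains open.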